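A methoxy swap with no measured starting point

A few compounds are considered here, and "the series" means these few. Any claim that something is new, unique, unknown or untested is made for them only; others in the source may bear on it.

Three related compounds share a core and differ in one aromatic group: compound 1 `Cc1cc(C)c(-c2nc(CN3CCC(C(=O)NCCCN4C[C@H](C)C[C@H](C)C4)CC3)c(C)o2)c(C)c1`, compound 2 `Cc1ccc(-c2nc(CN3CCC(C(=O)NCCCN4C[C@H](C)C[C@H](C)C4)CC3)c(C)o2)cc1C` and compound 3 `COc1cccc(OC)c1-c1nc(CN2CCC(C(=O)NCCCN3C[C@H](C)C[C@H](C)C3)CC2)c(C)o1`. Among the measured compounds shown here, in a physicochemical assay for permeability, using PAMPA (on this read-out higher numbers stand for higher permeability and lower numbers for lower permeability), compound 2 gives 219 10^-6 cm/s, the only real number in this small set. Compound 3 has no place on that scale yet: its entry reads "not determined" (no result reported), so there is no single number for it. Compound 1 is in the same position, with the entry "not determined" (no result reported).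

The next compound to be tested is compound 4 `COc1ccc(-c2nc(CN3CCC(C(=O)NCCCN4C[C@H](C)C[C@H](C)C4)CC3)c(C)o2)cc1OC`. The structural change is 3,4-dimethoxyphenyl in place of 2,6-dimethoxyphenyl on an aromatic carbon. Put simply, 3,4-dimethoxyphenyl stands in place of 2,6-dimethoxyphenyl on an aromatic carbon, so the atoms stay the same and are only joined differently.

For the measured compounds named here, no measured pair in this set shows how far a change of this kind moves this assay. Without a number for compound 3, a step from it cannot be sized, and no direction can be given. Going by the values given here, the only guide is compound 2 at 219 10^-6 cm/s, and a result that differs from this value by no more than the usual scatter is the expectation. Compound 4 is therefore estimated at 170 10^-6 cm/s, with an expected range from 70 10^-6 cm/s to 350 10^-6 cm/s.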

Compound 4, apparent permeability: 81.9 10^-6 cm/s
Compound 4: the middle estimate sits 2.1-fold (0.32 log units) above what was measured; the measured number falls inside the stated range.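

This result gives the set its first measured step in this assay, since 3,4-dimethoxyphenyl in place of 3,4-dimethylphenyl, on the aromatic carbon of the five-membered ring, brings a 2.7-fold lower number from compound 2 to compound 4 (0.43 log units; beyond the scatter) and so moves the read-out by more than the usual scatter. At this position, then, replacing the two methyl groups with two methoxy groups is not a neutral exchange in this assay, although that conclusion rests on a single pair of compounds. Steps involving compound 1 or compound 3 cannot be read, so the change from 2,6-dimethoxyphenyl to 3,4-dimethoxyphenyl still has no measured size, and no measurement here accounts for the lower number.

The compounds shown leave open whether both methoxy groups are needed for this step or one alone would produce it, a question that a phenyl ring bearing one methoxy group and one methyl group could answer. They also leave open how this assay would respond to a different kind of group at this place, such as a phenyl ring bearing a chlorine atom or a pyridine ring.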